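Amide aryl swap in a diaryl ether toll-like receptor 8 series

The source may hold more compounds than are shown below. What is called first, only, known or untested is meant among the compounds shown, and "the series" means these compounds.

Measured compounds:
compound 1, `O=C(Nc1ccc(Oc2cc(C(F)(F)F)cc(C(F)(F)F)c2)cc1)c1cc(I)ccc1F`: "not determined" (no result reported)
compound 2, `O=C(Nc1ccc(Oc2cc(C(F)(F)F)cc(C(F)(F)F)c2)cc1)c1ccc(I)cc1F`: > 50000 nM

Two compounds share the diaryl ether anilide core, differing only in the aryl group on the carbonyl carbon. For compound 1 the result in an assay on HEK293 cells for inhibition of Toll-like receptor 8 (Homo sapiens), with a stated time of 16 h (on this read-out higher numbers stand for weaker inhibition and lower numbers for stronger inhibition), is "not determined" (no result reported). Compound 2 returns only a limit in this assay, > 50000 nM. For the measured compounds named here, compound 2 therefore sits at the limit of > 50000 nM in this assay, at which 1 of the 2 values shown sits, and no numerical step between measured compounds can be drawn from the two entries.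

The next compound, compound 3, `O=C(Nc1ccc(Oc2cc(C(F)(F)F)cc(C(F)(F)F)c2)cc1)c1sccc1Cl`, is made from compound 2 by the change (3-chlorothiophen-2-yl in place of 2-fluoro-4-iodophenyl on a carbonyl carbon). Going by the values given here, no measured step of this kind exists in the set, so the expectation rests on compound 2 alone, whose entry in this assay is a limit, > 50000 nM. For compound 3 the step from compound 2 is expected to be small, an at least 1.2-fold lower number from compound 2 to compound 3 (0.09 log units; that floor lies within the scatter), with no firm direction beyond the scatter. The estimate for compound 3 in this assay is 40000 nM, within a range from 8000 nM to 120000 nM, and a further limit-only result remains a real possibility.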

Compound 3, half-maximal inhibitory concentration: 3200 nM
Compound 3: the middle estimate sits 13-fold (1.10 log units) above what was measured; the whole stated range lies above it.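

In this assay, the group on the carbonyl carbon whose other neighbour is the amide-type nitrogen turns out to control the read-out: 3-chlorothiophen-2-yl in place of 2-fluoro-4-iodophenyl gives an at least 15-fold lower number from compound 2 to compound 3 (1.19 log units; beyond the scatter), so this position tolerates a change that takes the series from a limit to a single number. Compound 2 carries only a limit, > 50000 nM, and not a number. On these data alone, the true size of the change stays unknown and the printed step is only a floor, because the starting point of the comparison is a limit: the limit of > 50000 nM in this assay, at which 1 of the 3 values shown sits.

The change replaces the ring, the hetero atom and the halogens all at once, so the compounds shown do not separate which of these parts carries the step. Also open, as far as these compounds go, is whether the gain survives with a methyl group or an amine in place of the chlorine of 3-chlorothiophen-2-yl, or with a plain phenyl group on the same carbonyl carbon.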